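A Fluorine Added to Compound 3

The compounds below may be only part of what the source reports. "The series", "measured", "known", "first", "only" and "open" are said of these compounds alone.

Three related compounds have been measured in an assay on isolated protein for inhibition of Ca2+/calmodulin-dependent protein kinase II (CaM kinase II) (Rattus norvegicus), tested at 30 uM; a higher number here means more inhibition at the concentration tested (going by the name of the read-out), a lower number less inhibition. Compound 1 `Cn1cnc2c(Sc3ccc(F)cc3)ncnc21` gives 5%, compound 2 `Cn1c(-c2ccccc2)nc2c(Sc3ccc(F)cc3)ncnc21` gives 8%, and compound 3 `CSc1ccc(-c2nc3c(Sc4ccccc4)ncnc3n2C)cc1` gives 0%. Among the measured compounds shown here, the only step between two compounds differing in a single place, a number 3 percentage points higher from compound 1 to compound 2 (within the scatter), stays within the scatter. Compound 3 has the lowest of the three numbers, but its gaps to compound 1 and to compound 2 are both within the scatter, so the three compounds cannot be set in order.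

Compound 4 `CSc1ccc(-c2nc3c(Sc4ccc(F)cc4)ncnc3n2C)cc1` has not yet been measured. It differs from compound 3 in one place: fluoro in place of hydrogen on an aromatic carbon, so that phenylsulfanyl becomes (4-fluorophenyl)sulfanyl. For the measured compounds named here, no measured step makes this same change; the single step on hand, a number 3 percentage points higher from compound 1 to compound 2 (within the scatter), concerns another part of the shared core and was within the scatter. Nothing in the data therefore points to a step in this assay beyond the scatter in either direction. Compound 4 is accordingly expected to give 3%, between -8% and 13%. The step this estimate implies, a number 3 percentage points higher from compound 3 to compound 4 (within the scatter), is expected to stay within the scatter.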

Compound 4, a percentage reported as inhibition, at one concentration (the size of the read-out at that concentration, not a potency): 7%
Beside the measured number, compound 4's estimate is 4 percentage points below it; the range from low to high includes it.
By their numbers in this assay, from the lowest: compounds 3, 1, 4 and 2 (each within the scatter of the next).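

In this assay the change from phenylsulfanyl to (4-fluorophenyl)sulfanyl can now be read directly, and fluoro in place of hydrogen on this aromatic carbon gives a number 7 percentage points higher from compound 3 to compound 4 (within the scatter) without leaving the scatter. The two further steps concern another place on the shared core: methylsulfanyl in place of hydrogen gives a number 1 percentage points lower from compound 2 to compound 4 (within the scatter) and 4-(methylsulfanyl)phenyl in place of hydrogen gives a number 2 percentage points higher from compound 1 to compound 4 (within the scatter), so neither of these additions separates the compounds either. No measurement on hand explains these numbers.

The compounds shown leave open whether an amine or a carboxylic acid in place of this fluoro would give a step beyond the scatter. They also leave open whether a longer chain in place of the methylsulfanyl group would do so.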